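Urea in place of methoxyethylamine on the tetralin side chain

A few compounds are considered here, and "the series" means these few. Any claim that something is new, unique, unknown or untested is made for them only; others in the source may bear on it.

Measured compounds in an assay on isolated protein for displacement of a labelled ligand from 5-hydroxytryptamine receptor 6 (Homo sapiens); a lower number here means a stronger inhibitor, a higher number a weaker inhibitor:
compound 1, `O=S(=O)(c1cccc(F)c1)c1ccc2c(c1)CCC[C@H]2CN1CCCS1(=O)=O`, 31.6 nM
compound 2, `CN(CC(N)=O)C[C@@H]1CCCc2cc(S(=O)(=O)c3cccc(F)c3)ccc21`, 1.26 nM
compound 3, `COCCNC[C@@H]1CCCc2cc(S(=O)(=O)c3cccc(F)c3)ccc21`, 0.251 nM

Compound 3 has the lowest number of the three. The step of a 5.0-fold lower number from compound 2 to compound 3 (0.70 log units; beyond the scatter) is modest, and the step of a 130-fold lower number from compound 1 to compound 3 (2.10 log units; beyond the scatter) is large, so compound 3 stands clearly apart from both.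

Compound 4, `CN(C)C(=O)NC[C@@H]1CCCc2cc(S(=O)(=O)c3cccc(F)c3)ccc21`, has not yet been measured in this assay. Compared with compound 3 the change is dimethylcarbamoyl in place of 2-methoxyethyl on an amine nitrogen. The amine nitrogen that carries the side chain in compound 3 thus becomes part of a urea in compound 4.

Among the compounds with values here, two measured steps bear on this. The step of a 25-fold lower number from compound 1 to compound 2 (1.40 log units; beyond the scatter) and the step of a 130-fold lower number from compound 1 to compound 3 (2.10 log units; beyond the scatter) both show that the substituent on the chain carbon matters strongly, and compound 1, whose nitrogen is bound within a sulfur-containing ring rather than carrying a simple alkyl group, gives the highest number. The step of a 5.0-fold lower number from compound 2 to compound 3 (0.70 log units; beyond the scatter) shows that even a change kept on the same nitrogen moves the number beyond the scatter. A dimethylcarbamoyl group on the nitrogen is a larger departure from compound 3 than compound 2 is, so a step toward a higher number is expected, a 32-fold higher number from compound 3 to compound 4 (1.50 log units; beyond the scatter). Compound 4 is estimated at 8 nM, between 1.5 nM and 50 nM.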

Compound 4, inhibition constant: 2.51 nM
Compound 4: the middle estimate sits 3.2-fold (0.50 log units) above what was measured; measured number inside the range.
By their numbers in this assay, from the lowest: compound 3; then compounds 2 and 4 (each within the scatter of the next); then compound 1.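

In this assay, the amine nitrogen that carries the side chain can become part of a urea at a modest cost, seen as a 10-fold higher number from compound 3 to compound 4 (1.00 log units; beyond the scatter), so 2-methoxyethyl on this nitrogen gives the lower number of the two groups. The step of a 2.0-fold higher number from compound 2 to compound 4 (0.30 log units; within the scatter) places the (dimethylcarbamoyl)amino group of compound 4 level with the (carbamoylmethyl)(methyl)amino group of compound 2, so these two differently built side chains cannot be told apart in this assay. The urea also retains most of the advantage over the five-membered ring group of compound 1, with a 13-fold lower number from compound 1 to compound 4 (1.10 log units; beyond the scatter), which shows that an open-chain group on the chain carbon need not be an amine of the kind in compound 3 to give a much lower number than compound 1.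

The data shown give no explanation for these steps. They also leave open whether the two methyl groups of the urea contribute to its number, a question that a urea ending in a plain amino group, a pyrrolidine-1-carbonyl group or a simple acetyl group on the same nitrogen would address.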